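The source may report more compounds than this note shows. Statements on the series, on what has been measured and on what is new or still open speak of the compounds shown alone.

Working notes on a small set tested in an assay on Sf9 cells for inhibition of protein deacetylase HDAC6 (Homo sapiens), read by fluorescence, with a stated time of 40 min, tested at 100 nM; a lower number here means less inhibition, a higher number more inhibition at the concentration tested (going by the name of the read-out). Compound 1 `O=C(NO)c1ccc(NCc2nc(-c3ccc(Cl)cc3)nn2-c2ccccc2)cc1` gives 67.2% in this assay. Compound 2 `NC(=O)c1ccc(NCc2nc(-c3ccccc3)nn2-c2ccccc2)cc1` gives -4.4% in this assay; compound 2 thereby stands lowest of the two numbers, and its nearest neighbour, compound 1, sits beyond the scatter above it. Going by the values given here, no step between measured compounds differing in one place is available, so the two values can only be set side by side. Compound 3 `O=C(NO)c1ccc(NCc2nc(-c3ccccc3)nn2-c2ccccc2)cc1` is not yet measured. Compound 3 differs from compound 2 by hydroxy in place of hydrogen on an amide-type nitrogen. Compound 1 carries the same hydroxycarbamoyl group and gives 67.2%, which is the only pointer at hand. The step expected from compound 2 to compound 3 is a number 59.4 percentage points higher from compound 2 to compound 3 (beyond the scatter), an increase well beyond the scatter. Compound 3 is estimated at 55%, with a range from 30% to 75%.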

Compound 3, a percentage reported as inhibition, at one concentration (the size of the read-out at that concentration, not a potency): 72.6%
Estimate against measurement, compound 3: 17.6 percentage points below; measured number inside the range.
By their numbers in this assay, from the lowest: compound 2; then compounds 1 and 3 (each within the scatter of the next).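

In this assay, hydroxy in place of hydrogen on the amide-type nitrogen gives a number 77 percentage points higher from compound 2 to compound 3 (beyond the scatter), so within this matched pair the change from carbamoyl to hydroxycarbamoyl alone separates a negligible read-out from a clear one. Hydrogen in place of chloro on an aromatic carbon gives a number 5.4 percentage points higher from compound 1 to compound 3 (within the scatter), so the chloro group makes no difference that can be read at this concentration in the compounds that carry hydroxycarbamoyl. No measured evidence bears on the reason for either step.

As far as these compounds go, whether a carboxylic acid or a methoxyamide in place of the hydroxycarbamoyl group would keep any of the read-out remains open. A percentage at one concentration is not a potency, so compound 1 and compound 3 could still separate in a full concentration series.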